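The source may report more compounds than this note shows. Statements on the series, on what has been measured and on what is new or still open speak of the compounds shown alone.

Series notes. Compound 1 `Cc1cccc(C#Cc2ccc3c(n2)CCN(C2CCCC2)C3=O)c1`, compound 2 `Cc1ccc(C#Cc2ccc3c(n2)CCN(C2CCCC2)C3=O)cc1` and compound 3 `COc1cccc(C#Cc2ccc3c(n2)CCN(C2CCCC2)C3=O)c1` share one core and differ only in the aryl group on the triple-bonded carbon. In a functional assay on HEK293 cells for positive allosteric modulation of metabotropic glutamate receptor 5 (Homo sapiens), read by FLIPR and calcium flux (on this read-out higher numbers stand for an effect only at larger amounts of compound and lower numbers for an effect already at smaller amounts), compound 1 gives 7.5 nM, compound 2 gives 4820 nM and compound 3 gives 462 nM, so compound 3 stands second highest of the three numbers. The steps of a 640-fold higher number from compound 1 to compound 2 (2.81 log units; beyond the scatter), a 62-fold higher number from compound 1 to compound 3 (1.79 log units; beyond the scatter) and a 10-fold lower number from compound 2 to compound 3 (1.02 log units; beyond the scatter) show that small changes at this group move the read-out strongly. Compound 4 `O=C1c2ccc(C#Cc3cccs3)nc2CCN1C1CCCC1` carries the change (thiophen-2-yl in place of 3-methoxyphenyl on a triple-bonded carbon). For the measured compounds named here, no measured step swaps the six-membered ring for a five-membered one, so those steps only set the scale of what is possible. A moderately lower number is expected, a 3.1-fold lower number from compound 3 to compound 4 (0.49 log units; beyond the scatter). Compound 4 is therefore estimated at 150 nM, within a range from 20 nM to 1500 nM.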

Compound 4, half-maximal effective concentration: 12 nM
Compound 4: the middle estimate sits 13-fold (1.10 log units) above what was measured, and the stated range ends above it.
By their numbers in this assay, from the lowest: compounds 1 and 4 (each within the scatter of the next); then compound 3; then compound 2.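

On the triple-bonded carbon, thiophen-2-yl gives a low number without a six-membered aromatic ring of carbon only: a 39-fold lower number from compound 3 to compound 4 (1.59 log units; beyond the scatter) and a 400-fold lower number from compound 2 to compound 4 (2.60 log units; beyond the scatter), while a 1.6-fold higher number from compound 1 to compound 4 (0.20 log units; within the scatter) stays within the scatter. A low number at this place is therefore not limited to 3-methylphenyl, and a five-membered aromatic ring with one hetero atom serves equally. Nothing available explains this result. Still open, as far as these compounds go, is whether furan-2-yl, thiophen-3-yl or a pyridine ring on the triple-bonded carbon also gives a low number. Also open, from the compounds shown here alone, is what a methyl group or a chlorine atom on the thiophen-2-yl would do.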